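The source may hold more compounds than are shown below. What is called first, only, known or untested is meant among the compounds shown, and "the series" means these compounds.

Compound 1 `COc1ccc(C2=Cc3ccc([N+](=O)[O-])cc3C(CC(C)=O)N2c2ccc(F)cc2)cc1` gives 7700 nM in an ADME assay on TZM cells (Homo sapiens) for cytotoxicity, read by CellTiter-Glo, with a stated time of 48 h; on this read-out higher numbers stand for lower toxicity in this test and lower numbers for higher toxicity in this test. Compound 2 `COc1ccc(C2=Cc3ccc([N+](=O)[O-])cc3C(CC(C)=O)N2c2ccc(C#N)cc2)cc1` differs from it by cyano in place of fluoro on an aromatic carbon and in this assay compound 2 gives 15400 nM, a step of a 2.0-fold higher number from compound 1 to compound 2 (0.30 log units; within the scatter). Compound 3 `COc1ccc(C2=Cc3ccc(F)cc3C(CC(=O)C(C)O)N2c2ccc(F)cc2)cc1` rests on a different core; the difference between its core and that of compound 1 is not broken down here. In this assay compound 3 gives 14000 nM, which lies within the scatter of compound 2 and of compound 1 alike. Compound 4 `COc1ccc(C2=Cc3ccc(F)cc3C(CC(=O)C(C)O)N2c2ccc(C#N)cc2)cc1` carries the same change, (cyano in place of fluoro on an aromatic carbon), made on the core of compound 3. Because a 2.0-fold higher number from compound 1 to compound 2 (0.30 log units; within the scatter) stayed within the scatter, a step of similar size, a 1.8-fold higher number from compound 3 to compound 4 (0.25 log units; within the scatter), is expected here, resting on that one earlier pair alone. Compound 4 is therefore expected to give about 25000 nM in this assay, most likely between 12000 nM and 55000 nM.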

Compound 4, half-maximal cytotoxic concentration: 24100 nM
For compound 4 the middle estimate is 1.0-fold (0.02 log units) above the measured one, and the stated range covers the measured number.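

In this assay, cyano in place of fluoro on the core of compound 3 gives a 1.7-fold higher number from compound 3 to compound 4 (0.24 log units; within the scatter). Set beside the earlier pair, the change carries from one core to the other with no difference that can be told apart: the same change on two cores in this assay, a 2.0-fold higher number (0.30 log units; within the scatter) from compound 1 to compound 2 and a 1.7-fold higher number (0.24 log units; within the scatter) from compound 3 to compound 4, 1.2-fold (0.07 log units) apart, within the scatter of two such steps. This rests on two pairs only, and since each step lies within the scatter, it shows agreement between the two cores but does not show that the change truly shifts the number on either core or that the agreement would extend to further cores.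

The compounds shown hold only fluoro or cyano at this place on the aromatic ring. Going by these compounds, how an amine or a carboxylic acid there would read in this assay remains open.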